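A few compounds are considered here, and "the series" means these few. Any claim that something is new, unique, unknown or untested is made for them only; others in the source may bear on it.

Compound 1 `N#Cc1cnc(NCc2ccccc2C(F)(F)F)cc1N[C@H]1CC[C@@H](O)CC1`: in an assay on isolated protein for inhibition of protein kinase C delta type (Homo sapiens), read by TR-FRET, with a stated time of 2 h (on this read-out higher numbers stand for weaker inhibition and lower numbers for stronger inhibition), compound 1 gives 4500 nM.
Compound 2 `N#Cc1cnc(NCc2ccccc2C(F)(F)F)cc1N[C@H]1CC[C@@H](C(N)=O)CC1`: in this assay compound 2 gives 640 nM.
Compound 3 `N#Cc1cnc(NCc2ccccc2)cc1N[C@H]1CC[C@@H](O)CC1`: in this assay compound 3 reaches only the limit of > 10000 nM.

Compound 3 thus stands at the limit of > 10000 nM in this assay, at which 1 of the 3 values shown sits, with no number of its own, while compounds 1 and 2 both give numbers. Compound 4 `COc1ncncc1CNc1cc(N[C@H]2CC[C@@H](O)CC2)c(C#N)cn1` differs from compound 3 by 4-methoxypyrimidin-5-yl in place of phenyl on a saturated chain carbon bound to a nitrogen on an aromatic ring. Of the measured steps, only an at least 2.2-fold higher number from compound 1 to compound 3 (0.34 log units; beyond the scatter) concerns the same ring, and it shows that what sits on that ring moves the number; a 7.0-fold lower number from compound 1 to compound 2 (0.85 log units; beyond the scatter) concerns the saturated ring and does not bear on this change. Going by the values given here, no measured step covers a heteroaryl swap, so the size is uncertain. Compound 4 is expected to give 6000 nM, between 1500 nM and 20000 nM, an expected step of an at least 1.6-fold lower number from compound 3 to compound 4 (0.22 log units; that floor lies within the scatter), and it may again fall at the limit.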

Compound 4, half-maximal inhibitory concentration: 800 nM
Beside the measured number, compound 4's estimate is 7.5-fold (0.88 log units) above it; measured number below the stated range.
By their numbers in this assay, from the lowest: compounds 2 and 4 (each within the scatter of the next); then compound 1. At a limit, above all of these: compound 3.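

On the saturated chain carbon bound to a nitrogen on an aromatic ring, 4-methoxypyrimidin-5-yl in place of phenyl gives an at least 12-fold lower number from compound 3 to compound 4 (1.09 log units; beyond the scatter) in this assay, so this position, where earlier only a phenyl with or without trifluoromethyl was shown, also takes a heteroaryl ring and moves the number strongly. The true size of the step stays unknown, as compound 3 has only a limit: the limit of > 10000 nM in this assay, at which 1 of the 4 values shown sits.

On these data alone, it remains open whether the methoxy group or the ring nitrogens carry the change, which a plain pyrimidin-5-yl or a methoxypyridinyl group would separate. Also open, as far as these compounds go, is whether carbamoyl on the saturated ring would lower the number further alongside 4-methoxypyrimidin-5-yl.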